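The source may hold more compounds than are shown below. What is called first, only, known or untested is meant among the compounds shown, and "the series" means these compounds.

Among the compounds with values here, compound 1 `COc1ccc(Nc2nc(-c3cccc(F)c3)nc3ccc(F)cc23)cc1` is the only member of the series that returns a number in a functional assay on MDA-MB-231 cells (Homo sapiens) for cytotoxicity, read by MTT assay, with a stated time of 48 h; a higher number here means a weaker inhibitor, a lower number a stronger inhibitor: compound 1 gives 47300 nM. Compound 2 `COc1ccccc1Nc1nc(-c2cccc(F)c2)nc2ccc(F)cc12` reaches only a limit of the same test, compound 2 giving > 50000 nM. Compound 3 `Fc1cccc(-c2nc(Nc3ccccc3Cl)c3cc(F)ccc3n2)c1` likewise stops at a limit, compound 3 giving > 50000 nM. Both steps away from compound 1 are therefore floors rather than sizes: an at least 1.0-fold higher number from compound 1 to compound 2 (0.02 log units; that floor lies within the scatter) and an at least 1.0-fold higher number from compound 1 to compound 3 (0.02 log units; that floor lies within the scatter). The step that the two limits leave unreadable from compound 2 to compound 3 cannot be read at all. Two of the three values sit at the limit of > 50000 nM in this assay, at which 2 of the 3 values shown sit.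

Compound 4 `Cc1ccccc1Nc1nc(-c2cccc(F)c2)nc2ccc(F)cc12` has not yet been measured. Its change from compound 1 is 2-methylphenyl in place of 4-methoxyphenyl on a nitrogen on an aromatic ring. Within the data shown here, the two measured changes at the same nitrogen, 2-methoxyphenyl and 2-chlorophenyl in place of 4-methoxyphenyl, both carried the value from a number to the limit, and no measured step separates a 2-methylphenyl from either of them. The expectation is thus a value at or past the limit, and in any case not a fall beyond the scatter relative to compound 1. Compound 4 is expected at 60000 nM, with a range from 30000 nM to 120000 nM. The step that this estimate means is a 1.3-fold higher number from compound 1 to compound 4 (0.10 log units; within the scatter).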

Compound 4, half-maximal inhibitory concentration: > 50000 nM
Compound 4: only a limit was reported (the forecaster's own chance of this, stated with the estimate: 65%); the middle value lies beyond the limit too.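

Compound 4 brings a 2-methylphenyl onto the nitrogen, a group with no hydrogen-bond acceptor, and in this assay compound 4 gives > 50000 nM, which is a limit of the assay and not a number. The change from 4-methoxyphenyl therefore has only a floor, an at least 1.0-fold higher number from compound 1 to compound 4 (0.02 log units; that floor lies within the scatter), and the steps from compound 2 and from compound 3 to compound 4 cannot be read. New here is that methyl now joins methoxy and chloro in the same outcome, so all three groups named as 2-substituted phenyl rings in compound 2, compound 3 and compound 4 stop at the same limit, with none of the three going against this, while compound 1 alone returns a number, and that number is not separated from the limit by more than the scatter: the limit of > 50000 nM in this assay, at which 3 of the 4 values shown sit.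

Whether any group on this nitrogen can bring the value clearly under the limit stays open, since the only number shown lies close to it. A 4-aminophenyl, a 4-carboxyphenyl or a 3-methoxyphenyl at the same nitrogen would test this, and the shared core and its 3-fluorophenyl stay unvaried throughout the compounds shown.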